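The compounds below may be only part of what the source reports. "The series", "measured", "known", "first", "only" and "open" are said of these compounds alone.

In a functional assay on A549 cells (Homo sapiens) for inhibition, read by sulforhodamine B assay, with a stated time of 72 h (a lower number here means a stronger inhibitor, a higher number a weaker inhibitor), the three measured compounds are:
compound 1 `COc1cc2c(Nc3ccc(F)c(Cl)c3)ncnc2cc1OCCCCCCn1ccnc1[N+](=O)[O-]`, 6520 nM;
compound 2 `COc1cc2c(Nc3ccc(F)c(Cl)c3)ncnc2cc1OCCOCCn1ccnc1[N+](=O)[O-]`, 7640 nM;
compound 3 `C#Cc1cccc(Nc2ncnc3cc(OCCOCCn4ccnc4[N+](=O)[O-])c(OC)cc23)c1`, 6430 nM.

Among these numbers compound 1 has the second highest, and all three lie within the scatter of one another. Compound 4 `COc1cc2c(Nc3ccc(OCc4cccc(F)c4)c(Cl)c3)ncnc2cc1OCCCCCCn1ccnc1[N+](=O)[O-]` differs from compound 1 by (3-fluorobenzyl)oxy in place of fluoro on an aromatic carbon. For the measured compounds named here, no measured step touches this position. The two steps at hand, a 1.2-fold higher number from compound 1 to compound 2 (0.07 log units; within the scatter) and a 1.2-fold lower number from compound 2 to compound 3 (0.07 log units; within the scatter), alter the chain and the group on the nitrogen, and both stay within the scatter. Nothing here speaks for a step beyond the scatter in this assay, though the change is large and untested. The value of compound 4 is therefore expected to be 6000 nM, with a range of 2000 nM to 18000 nM. This estimate means an expected step of a 1.1-fold lower number from compound 1 to compound 4 (0.04 log units; within the scatter).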

Compound 4, half-maximal inhibitory concentration: > 50000 nM
Compound 4: only a limit was reported; the forecaster's own chance of this, stated with the estimate: 5%; middle value at least 8.3-fold (0.92 log units) from the limit.
By their numbers in this assay, from the lowest: compounds 3, 1 and 2 (each within the scatter of the next). At a limit, above all of these: compound 4.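

Putting (3-fluorobenzyl)oxy in place of fluoro on the aromatic carbon ortho to the chloro group gives an at least 7.6-fold higher number from compound 1 to compound 4 (0.88 log units; beyond the scatter) in this assay. Unlike the earlier changes to the chain and to the group on the nitrogen, this change moves the number beyond the scatter. Compound 4 stands at a limit, not at an exact number: the limit of > 50000 nM in this assay, at which 1 of the 4 values shown sits.

The compounds shown leave open whether an amine or a methoxy group at this position would also move the number. They also leave open whether the same change would act alike with the chain of compound 2.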